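Piperazine substituents and antiproliferative inhibition on HeLa cells

A few compounds are considered here, and "the series" means these few. Any claim that something is new, unique, unknown or untested is made for them only; others in the source may bear on it.

Measured compounds:
compound 1 `Nc1ccccc1NC(=O)c1ccc(CSC(=S)N2CCN(C3CCCCC3)CC2)cc1`: 76.1%
compound 2 `Nc1ccccc1NC(=O)c1ccc(CSC(=S)N2CCN(c3ccccc3F)CC2)cc1`: 59.2%
compound 3 `Nc1ccccc1NC(=O)c1ccc(CSC(=S)N2CCN(c3cnccn3)CC2)cc1`: 76.9%

In a functional assay on HeLa cells (Homo sapiens) for antiproliferative activity, read by CCK-8 assay, with a stated time of 72 h, tested at 8 uM (a higher number here means a stronger effect of the compound at the concentration tested, a lower number a weaker effect), compound 3 gives the highest of the three numbers, though its gap to compound 1 lies within the scatter, as a number 0.8 percentage points higher from compound 1 to compound 3 (within the scatter) shows; only compound 2 stands clearly apart, as a number 17.7 percentage points higher from compound 2 to compound 3 (beyond the scatter) shows. Compound 4 `Cc1ccc(N2CCN(C(=S)SCc3ccc(C(=O)Nc4ccccc4N)cc3)CC2)cc1` has not yet been measured. It differs from compound 3 in one place: 4-methylphenyl in place of pyrazin-2-yl on an amine nitrogen in a ring.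

For the measured compounds named here, two measured steps bear on this change. Going from a cyclohexyl to an aromatic ring of carbon gave a number 16.9 percentage points lower from compound 1 to compound 2 (beyond the scatter), whereas the aromatic ring bearing two nitrogens gave a number 0.8 percentage points higher from compound 1 to compound 3 (within the scatter). Going by the values given here, the entering 4-methylphenyl is a carbon-only aromatic ring, as in compound 2, so a modest drop in this assay is expected, but no exact counterpart exists and the scatter is wide. The expected step is a number 11.9 percentage points lower from compound 3 to compound 4 (beyond the scatter). For compound 4 the estimate in this assay is 65%, within a range from 50% to 80%.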

Compound 4, a percentage reported as inhibition, at one concentration (the size of the read-out at that concentration, not a potency): 24%
Beside the measured number, compound 4's estimate is 41 percentage points above it; the whole stated range lies above it.
By their numbers in this assay, from the lowest: compound 4; then compound 2; then compounds 1 and 3 (each within the scatter of the next).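

In this assay, for the compounds shown here, the change to 4-methylphenyl on the amine nitrogen in the ring shows that this position can lose far more of the effect than the earlier compounds revealed, with a number 52.9 percentage points lower from compound 3 to compound 4 (beyond the scatter) and a number 52.1 percentage points lower from compound 1 to compound 4 (beyond the scatter). Nor does a carbon-only aromatic ring set the level by itself, since 2-fluorophenyl and 4-methylphenyl stand well apart, with a number 35.2 percentage points lower from compound 2 to compound 4 (beyond the scatter). No measurement given here bears on what lies behind this drop.

On these data alone, it remains open whether the loss goes with the methyl group or with where it sits on the ring, a question that an unsubstituted phenyl, a 4-fluorophenyl or a 2-methylphenyl on the same nitrogen would address. A read-out at one concentration also gives no potency for any of these compounds.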